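Swapping the amide for an aminopyrazine on the shared core

A few compounds are considered here, and "the series" means these few. Any claim that something is new, unique, unknown or untested is made for them only; others in the source may bear on it.

Of the compounds shown here, two sharing one core have been measured. Compound 1 `CCN1CCN(c2cccc3c2CN([C@H](CCCNC(=O)c2c(C)n[nH]c2C)c2ccc(OC)c(OC)c2)C3=O)CC1` gives 11 nM in an assay on RMS13 cells for displacement of a labelled ligand from Urotensin-2 receptor (Homo sapiens), read by scintillation proximity assay; on this read-out higher numbers stand for weaker inhibition and lower numbers for stronger inhibition. Compound 2 `CCN1CCN(c2cccc3c2CN([C@H](CCCNC(=O)c2cccs2)c2ccc(OC)c(OC)c2)C3=O)CC1` gives 18 nM; this is the higher of the two numbers, but the step of a 1.6-fold higher number from compound 1 to compound 2 (0.21 log units; within the scatter) lies within the scatter, so the two compounds cannot be told apart on these data.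

Compound 3 `CCN1CCN(c2cccc3c2CN([C@H](CCCNc2cncc(OC)n2)c2ccc(OC)c(OC)c2)C3=O)CC1` has not yet been measured. It differs from compound 2 by 6-methoxypyrazin-2-yl in place of (thiophen-2-yl)carbonyl on an amine nitrogen. Among the compounds with values here, the one measured step exchanged one aromatic ring for another while keeping the carbonyl in place, and it made no difference beyond the scatter. Within the data shown here, the new change goes further: the carbonyl disappears and the aromatic ring sits directly on the amine nitrogen, so no measured step speaks directly to it. With only a single, neutral step as guide, a modest step is expected, most likely toward a higher number, with wide uncertainty: the expected step is a 2.2-fold higher number from compound 2 to compound 3 (0.35 log units; beyond the scatter). For compound 3 the estimate in this assay is 40 nM, expected to fall between 10 nM and 200 nM.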

Compound 3, inhibition constant: 8 nM
Beside the measured number, compound 3's estimate is 5.0-fold (0.70 log units) above it; measured number below the stated range.
By their numbers in this assay, from the lowest: compounds 3, 1 and 2 (each within the scatter of the next, the first and the last beyond it).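

In this assay, the carbonyl on this amine nitrogen proves dispensable among these compounds: putting 6-methoxypyrazin-2-yl directly on the nitrogen gives a 2.3-fold lower number from compound 2 to compound 3 (0.35 log units; beyond the scatter) and so a modest gain in inhibition rather than a loss. Against the other amide, the same kind of exchange gives a 1.4-fold lower number from compound 1 to compound 3 (0.14 log units; within the scatter) and the two compounds cannot be told apart, so this position holds both a (3,5-dimethyl-1H-pyrazol-4-yl)carbonyl group and a directly attached six-membered aromatic ring with 2 hetero atoms. No supporting evidence is available to explain why the exchange is tolerated.

The change removes the carbonyl and replaces the ring in a single move, so the effect of each remains unseparated; a 6-methoxypyrazine-2-carbonyl amide on the same chain would bear directly on that question. Also open, on these data alone, is whether the methoxy group matters, which could be tested with a plain pyrazin-2-yl ring or an amine in its place, and whether a longer chain would keep the inhibition.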